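Moving the chlorine around the ring in a hydrazone series

The source may report more compounds than this note shows. Statements on the series, on what has been measured and on what is new or still open speak of the compounds shown alone.

Measured so far in an ADME assay on NIH3T3 cells (Mus musculus) for cytotoxicity, read by XTT assay, with a stated time of 24 h; on this read-out higher numbers stand for weaker inhibition and lower numbers for stronger inhibition:
Compound 1, `Cn1nnnc1SCC(=O)N/N=C/c1ccc(F)cc1`: 10000000 nM
Compound 2, `Cn1nnnc1SCC(=O)N/N=C/c1cccc(F)c1`: 6320000 nM
Compound 3, `C/C(=N\NC(=O)CSc1nnnn1C)c1ccccc1Cl`: 6000000 nM

All three numbers sit close together. Compound 3 gives 6000000 nM; the nearest number belongs to compound 2 and the furthest to compound 1, and both lie within the usual scatter of this assay, so no real separation between them can be claimed.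

Compound 4, `C/C(=N\NC(=O)CSc1nnnn1C)c1ccc(Cl)cc1`, has not been measured. It differs from compound 3 only in one respect: 4-chlorophenyl in place of 2-chlorophenyl on a carbon with a double bond to nitrogen. Going by the values given here, no measured pair shows what such a change does here. Given how little the three measured numbers differ from one another, the step of a 1.1-fold higher number from compound 3 to compound 4 (0.03 log units; within the scatter) is expected to be none beyond the scatter. Compound 4 is therefore estimated at 6500000 nM, with a range from 3000000 nM to 13000000 nM.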

Compound 4, half-maximal inhibitory concentration: 100000 nM
Beside the measured number, compound 4's estimate is 65-fold (1.81 log units) above it, and the stated range ends above it.
By their numbers in this assay, from the lowest: compound 4; then compounds 3, 2 and 1 (each within the scatter of the next).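

In this assay the swap of 2-chlorophenyl for 4-chlorophenyl gives a 60-fold lower number from compound 3 to compound 4 (1.78 log units; beyond the scatter) and so stronger inhibition, although the two compounds hold exactly the same atoms. Where the chlorine sits on this ring therefore matters greatly, something the three closely grouped earlier numbers gave no hint of. Nothing available here accounts for the size of this step.

Going by these compounds, whether chlorine itself is needed remains open. An amine or a carboxylic acid in place of the chlorine could keep this stronger inhibition or lose it.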